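The source may report more compounds than this note shows. Statements on the series, on what has been measured and on what is new or still open speak of the compounds shown alone.

Compound 1 `CC(C)(O)[C@@H](O)Cc1c(O)cc2occ(-c3ccc(O)cc3)c(=O)c2c1O`: 25000 nM
Compound 2 `CC(C)(O)[C@@H](O)Cc1c(O)cc(O)c2c(=O)c(-c3ccc(O)cc3)coc12`: > 100000 nM
Compound 3 `COc1ccc([C@@H]2CCc3c(OC)cc(OC)cc3O2)cc1`: 21000 nM

Of the compounds shown here, three have been measured in a functional assay on U-937 cells (Homo sapiens) for antiproliferative activity, read by WST assay, with a stated time of 48 h; a lower number here means a stronger inhibitor, a higher number a weaker inhibitor. Compound 1 gives 25000 nM in this assay. For compound 2 the result in this assay is a limit, > 100000 nM, and not a number. Compound 3, built on a different core from the other two, gives 21000 nM in this assay; its number and that of compound 1 sit within the scatter of each other, so the two cannot be told apart on these data.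

Compound 4 `COc1cc(OC)c2c(c1)O[C@H](c1ccc(O)cc1)CC2` has not yet been measured. It differs from compound 3 in one place: hydrogen in place of methyl on an oxygen on an aromatic ring. Among the compounds with values here, no pair of measured compounds differs in only one place, so no measured step shows how such a change plays out here. A change of this kind is expected to move the number little, and the step of no change at the digits printed from compound 3 to compound 4 (within the scatter) is expected to stay within the scatter. Compound 4 is therefore estimated at 21000 nM, with a range from 8000 nM to 60000 nM.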

Compound 4, half-maximal inhibitory concentration: 40000 nM
Beside the measured number, compound 4's estimate is 1.9-fold (0.28 log units) below it; measured number inside the range.
By their numbers in this assay, from the lowest: compounds 3, 1 and 4 (each within the scatter of the next). At a limit, above all of these: compound 2.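

Within the data shown here, replacing methyl with hydrogen on an oxygen on an aromatic ring gives the first measured step in this set: in this assay, methoxy to hydroxy gives a 1.9-fold higher number from compound 3 to compound 4 (0.28 log units; within the scatter). A single repeat-level difference like this means the two compounds cannot be told apart, so on these data, this oxygen can carry either methyl or hydrogen with no measurable effect on the number. Nothing measured here gives a reason for the size of this step.

Going by these compounds, it remains open whether a larger group on this oxygen, such as a longer chain ending in an amine or a carboxylic acid, would move the number beyond the scatter. On these data alone, it is also open whether the same methoxy to hydroxy change would behave alike at the methoxy groups that remain on compound 4.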